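A Longer Hydroxyalkyl Chain on the Shared Core

The source may report more compounds than this note shows. Statements on the series, on what has been measured and on what is new or still open speak of the compounds shown alone.

Compound 2 `COc1ccc2cc(CO)oc(=O)c2c1` carries a methoxy group on an aromatic carbon of the core of compound 1 `O=c1oc(CO)cc2ccccc12`. In a functional assay on NCI-H460 cells (Homo sapiens) for antiproliferative activity, read by sulforhodamine B assay, with a stated time of 48 h (a higher number here means a weaker inhibitor of growth, a lower number a stronger inhibitor of growth), compound 1 reaches only the limit >= 250 ug/mL, which is a limit of the assay and not a number. In this assay, among the measured compounds shown here, compound 2 gives 93.2 ug/mL, the only number among the two values shown. For the measured compounds named here, the step of an at least 2.6-fold lower number from compound 1 to compound 2 (0.42 log units; beyond the scatter) is the sole measured step, and one end of it is the limit (the limit of >= 250 ug/mL in this assay, at which 1 of the 2 values shown sits). Compound 3 `COc1ccc2cc(CCCO)oc(=O)c2c1` differs from compound 2 by 2-hydroxyethyl in place of hydroxy on a saturated chain carbon bound to an aromatic carbon. Going by the values given here, no measured step bears on this change, which lengthens the chain while leaving the methoxy group and the core untouched. Compound 3 is therefore expected to stay near compound 2, with an estimated step of a 1.2-fold lower number from compound 2 to compound 3 (0.09 log units; within the scatter) not clearly beyond the scatter. Compound 3 is estimated at 75 ug/mL, within 25 ug/mL to 250 ug/mL.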

Compound 3, concentration for 50% growth inhibition: 29.1 ug/mL
Compound 3: the middle estimate sits 2.6-fold (0.41 log units) above what was measured; low and high end bracket the measured number.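

In this assay the change from hydroxymethyl to 3-hydroxypropyl gives a 3.2-fold lower number from compound 2 to compound 3 (0.51 log units; beyond the scatter), so the length of this chain alters the number, and the methoxy group is no longer the only change shown to do so. This is the first step shown with a measured number at both ends, so its full size can be read. Compound 1, at the other end of the earlier step, stands at a limit of the assay and not a number: the limit of >= 250 ug/mL in this assay, at which 1 of the 3 values shown sits.

The compounds shown leave open whether a chain longer than 3-hydroxypropyl would lower the number further, and whether an amine or a carboxylic acid at the chain end would serve in place of the hydroxy. They also leave open whether 3-hydroxypropyl would give a similar step on the shared core without the methoxy group.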